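This account rests on a few compounds, and the source may have more. Where it says the series, first, only, none or still open, it means among the compounds named here.

Compound 1 `CNC(=O)c1ccccc1Oc1nc(Nc2ccc(Br)cc2)ncc1Br`: 39700 nM
Compound 2 `CNC(=O)c1ccccc1Oc1nc(Nc2ccc(C(F)(F)F)cc2)ncc1Br`: > 50000 nM (a limit)

Going by the values given here, in a functional assay on HL-60 cells (Homo sapiens) for antiproliferative activity, read by MTT assay, with a stated time of 24 h (a higher number here means a weaker inhibitor, a lower number a stronger inhibitor), compound 1 gives 39700 nM, the only exact number available. Compound 2 gives > 50000 nM, which is a limit of this assay. Compound 3 `CNC(=O)c1ccccc1Oc1nc(Nc2ccccc2F)ncc1Br` carries 2-fluorophenyl in place of 4-bromophenyl on a nitrogen on an aromatic ring. Among the compounds with values here, the only measured step, an at least 1.2-fold higher number from compound 1 to compound 2 (0.10 log units; that floor lies within the scatter), replaces the bromo of that same 4-bromophenyl group with trifluoromethyl, and it bears only indirectly. On that basis, no change beyond the scatter is expected in this assay. The estimated step is a 1.1-fold lower number from compound 1 to compound 3 (0.05 log units; within the scatter). Compound 3 is expected at 35000 nM, within an estimated range of 15000 nM to 50000 nM.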

Compound 3, half-maximal inhibitory concentration: > 50000 nM
Compound 3 was reported as a limit; the forecaster's own chance of this, stated with the estimate: 30%; middle value at least 1.4-fold (0.15 log units) away from the limit.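

In this assay, 2-fluorophenyl in place of 4-bromophenyl on a nitrogen on an aromatic ring gives an at least 1.2-fold higher number from compound 1 to compound 3 (0.10 log units; that floor lies within the scatter), a floor within the scatter, so the true size of this change cannot be read. The value of compound 3 is a limit, not a number. A second, different replacement of this aryl group thus ends at the same limit, leaving compound 1 as the only exact value: the limit of > 50000 nM in this assay, at which 2 of the 3 values shown sit.

Going by these compounds, what 4-fluorophenyl or 2-bromophenyl would give on that nitrogen stays open, so the identity of the halogen and its place on the ring cannot be told apart. On these data alone, a 4-aminophenyl group or a carboxylic acid on that ring is equally open.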